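Swapping methoxy for difluoromethoxy on a cyclohexyl benzimidazole amide

The source may report more compounds than this note shows. Statements on the series, on what has been measured and on what is new or still open speak of the compounds shown alone.

Compound 1, with the structure `COc1ccc(C(=O)Nc2cc3nc(C4CCCCC4)[nH]c3cc2N(C)C)cc1`, has been tested in an ADME assay on Vero cells (Chlorocebus sabaeus) for cytotoxicity, read by resazurin assay, with a stated time of 3 days; a lower number here means a stronger inhibitor, a higher number a weaker inhibitor. In this assay compound 1 gives > 100 ug/mL, which is a limit of the assay rather than a number. Two close relatives have been run alongside it. Compound 2, `COc1ccc(C(=O)Nc2cc3nc(C4CCCCC4)[nH]c3cc2N2CCCC2)cc1`, carries pyrrolidin-1-yl in place of dimethylamino on an aromatic carbon; in this assay compound 2 gives > 100 ug/mL, again a limit. Compound 3, `Cc1ccc(C(=O)Nc2cc3nc(C4CCCCC4)[nH]c3cc2N2CCCC2)cc1`, carries methyl in place of methoxy on an aromatic carbon; in this assay compound 3 gives > 100 ug/mL, also a limit. The step that the two limits leave unreadable from compound 1 to compound 2 and the step that the two limits leave unreadable from compound 2 to compound 3 therefore cannot be sized, since (the limit of > 100 ug/mL in this assay, at which 3 of the 3 values shown sit).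

Compound 4, `CN(C)c1cc2[nH]c(C3CCCCC3)nc2cc1NC(=O)c1ccc(OC(F)F)cc1`, differs from compound 1 by difluoromethyl in place of methyl on an oxygen on an aromatic ring. Among the measured compounds shown here, no measured step reports a readable size, and every value so far is a limit, so the expectation for compound 4 rests on this silence alone: the step of a number no higher from compound 1 to compound 4 (the limit leaves the size open) is expected to stay within the scatter, with no direction called. On that basis compound 4 is estimated to give 100 ug/mL in this assay, in a range from 50 ug/mL to 200 ug/mL, most likely reported again as a limit.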

Compound 4, half-maximal inhibitory concentration: > 100 ug/mL
Compound 4 ended at the assay's limit; the forecaster's own chance of this, stated with the estimate: 85%; the middle value lies on the limit itself.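

In this assay compound 4 gives > 100 ug/mL, which is a limit of the assay and not a number. No size can be read for the change from methoxy to difluoromethoxy between compound 1 and compound 4, because both stand at a limit: the limit of > 100 ug/mL in this assay, at which 4 of the 4 values shown sit.

The compounds shown leave open what actual number any of the four would give, and so whether this change makes any difference to the read-out.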